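The source may report more compounds than this note shows. Statements on the series, on what has been measured and on what is new or still open speak of the compounds shown alone.

Measured so far:
- compound 2, `CCOc1cc(C2CCN(C)CC2)ccc1Nc1ncc2c(n1)N(Cc1cccc(C#N)c1)[C@H](CC)C(=O)N2C`: 1800 nM
- compound 3, `CC[C@@H]1C(=O)N(C)c2cnc(Nc3ccc(C4CCN(C)CC4)cc3OC)nc2N1C1CCCC1`: 9.9 nM
- compound 1, `CCOc1cc(C2CCN(C)CC2)ccc1Nc1ncc2c(n1)N(Cc1ccc(Br)cc1)[C@H](CC)C(=O)N2C`: "not determined" (no result reported)

All three share one core, and the measurements come from an assay on isolated protein for inhibition of serine/threonine-protein kinase PLK1 (Homo sapiens), read by Z'-LYTE, with a stated time of 60 min; on this read-out higher numbers stand for weaker inhibition and lower numbers for stronger inhibition. In this assay compound 2 gives 1800 nM, the higher of the two numbers available, while compound 3 gives 9.9 nM, a number far below it and well beyond the usual scatter of repeated measurements. Compound 1 carries a bromobenzyl group in the position where compound 2 carries its cyanobenzyl group, but for compound 1 the entry in this assay reads "not determined" (no result reported).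

The step under consideration leads from compound 2 to compound 4, `CCOc1cc(C2CCN(C)CC2)ccc1Nc1ncc2c(n1)N(Cc1ccccc1)[C@H](CC)C(=O)N2C`. The change is small: hydrogen in place of cyano on an aromatic carbon. Cut one bond further out, it reads as 3-cyanobenzyl to benzyl. Among the compounds with values here, no pair of measured compounds shows this change, so nothing in the data says which way it should go.

With that in mind, compound 4 is expected to stay close to compound 2, and the step of a 1.2-fold lower number from compound 2 to compound 4 (0.08 log units; within the scatter) is estimated to lie within the scatter rather than to mark a real gain or loss. For compound 4 in this assay, a value of 1500 nM is estimated, with a range from 400 nM to 5000 nM.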

Compound 4, half-maximal inhibitory concentration: 290 nM
For compound 4 the middle estimate is 5.2-fold (0.71 log units) above the measured one; measured number outside the range, below it.
By their numbers in this assay, from the lowest: compound 3; then compound 4; then compound 2.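

In this assay, replacing the nitrile with hydrogen gives a 6.2-fold lower number from compound 2 to compound 4 (0.79 log units; beyond the scatter). Within the data shown here, this is the only single-change comparison available so far, and it shows that this position on the benzyl ring affects the read-out: a plain benzyl group gives stronger inhibition than 3-cyanobenzyl, so the cyano group is not needed for inhibition in this pair. No accompanying measurement explains why the number moves in this direction.

A single pair cannot show whether the improvement comes from removing this particular cyano group or whether other groups on the same aromatic carbon would also give weaker inhibition than hydrogen. A fluorine atom, a methyl group, a methoxy group or an amine placed there would help separate these possibilities and show whether any substituent at this place can match or improve on plain benzyl.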